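Permeability notes: aryl amine series, benzyl variation at compound 3

The compounds below may be only part of what the source reports. "The series", "measured", "known", "first", "only" and "open" are said of these compounds alone.

Going by the values given here, compound 1 `FC(F)(F)c1ccc(-c2ccc3c(NCCCNCc4ccco4)ccnc3c2)cc1` gives 237 10^-6 cm/s in an ADME assay for permeability, using PAMPA, with a stated time of 30 min, at pH 7.4 (a lower number here means that the compound crosses the layer more slowly, a higher number that the compound crosses the layer faster), the highest of the two numbers so far. Compound 2 `CC(C)Cc1ccc2c(NCCCNCc3ccco3)ccnc2c1`, which carries isobutyl in place of 4-(trifluoromethyl)phenyl on an aromatic carbon, gives 23 10^-6 cm/s in this assay, a step of a 10-fold lower number from compound 1 to compound 2 (1.01 log units; beyond the scatter). Compound 3 `COc1cccc(CNCCCNc2ccnc3cc(-c4ccc(C(F)(F)F)cc4)ccc23)c1O` differs from compound 1 at the other end of the chain: 2-hydroxy-3-methoxyphenyl in place of furan-2-yl on a saturated chain carbon bound to an amine nitrogen. Among the compounds with values here, no measured step covers this change; the step from compound 1 to compound 2 concerns a different part of the shared core and says nothing direct about it. Within the data shown here, with no comparable measured step, the expectation for compound 3 rests on compound 1 alone, and the estimated step is a 2.0-fold lower number from compound 1 to compound 3 (0.30 log units; within the scatter), a number somewhat lower but near the edge of the scatter. Compound 3 is therefore expected to give about 120 10^-6 cm/s in this assay, within a range from 40 10^-6 cm/s to 300 10^-6 cm/s.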

Compound 3, apparent permeability: 237 10^-6 cm/s
Beside the measured number, compound 3's estimate is 2.0-fold (0.30 log units) below it; low and high end bracket the measured number.
By their numbers in this assay, from the lowest: compound 2; then compounds 1 and 3 (each within the scatter of the next).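

In this assay, going by these compounds alone, the first step at this end of the chain, with 2-hydroxy-3-methoxyphenyl in place of furan-2-yl, is no change at the digits printed from compound 1 to compound 3 (within the scatter). The change brings 9 heavy atoms in place of 5 and 1 hydrogen-bond donor in place of none, yet the read-out stays level, whereas the earlier step at the other place on the shared core was a 10-fold lower number from compound 1 to compound 2 (1.01 log units; beyond the scatter). No measurement at hand accounts for this result.

Open, from the compounds shown here alone, is whether the level result belongs to the whole 2-hydroxy-3-methoxyphenyl group or to one part of it, which a plain phenyl, a 2-hydroxyphenyl or a 3-methoxyphenyl group would separate. Also open, going by these compounds, are a carboxylic acid or a dimethylamino group on the same carbon, and whether the same exchange stays level with isobutyl in place of 4-(trifluoromethyl)phenyl.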